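Taking One Methoxy Group off Compound 2

The source may report more compounds than this note shows. Statements on the series, on what has been measured and on what is new or still open speak of the compounds shown alone.

In a functional assay on SW480 cells (Homo sapiens) for cytotoxicity, read by sulforhodamine B assay, with a stated time of 48 h (a higher number here means a weaker inhibitor, a lower number a stronger inhibitor), compound 1 (`COc1ccc(/C=C/C(=O)c2cccc(-c3ccc(F)cc3)c2)cc1`) gives 8350 nM and compound 2 (`COc1cccc(/C=C/C(=O)c2cccc(-c3cccc(F)c3)c2)c1OC`) gives 13500 nM. Going by the values given here, these two values lie within the usual scatter of repeated measurements, so compound 2 stands level with compound 1 on the numbers so far.

Compound 3 (`COc1ccccc1/C=C/C(=O)c1cccc(-c2cccc(F)c2)c1`) has hydrogen in place of methoxy on an aromatic carbon of compound 2 (hydrogen in place of methoxy on an aromatic carbon). Among the compounds with values here, no pair of measured compounds shows this single change, so the data offer no direct guide to its effect. The only basis is the closeness of compound 1 at 8350 nM and compound 2 at 13500 nM. In this assay, no step beyond the scatter is therefore expected. The estimated step of a 1.2-fold lower number from compound 2 to compound 3 (0.09 log units; within the scatter) is small. Compound 3 is expected to give about 11000 nM, within an estimated range of 5000 nM to 25000 nM.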

Compound 3, half-maximal inhibitory concentration: 16600 nM
Compound 3: middle estimate off by 1.5-fold (0.18 log units), on the low side; low and high end bracket the measured number.
By their numbers in this assay, from the lowest: compounds 1, 2 and 3 (each within the scatter of the next).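

Going by these compounds alone, this is the first comparison here between two compounds that differ in only one place. In this assay, putting hydrogen in place of the methoxy group that sits ortho to a methoxy group gives a 1.2-fold higher number from compound 2 to compound 3 (0.09 log units; within the scatter) and so does not move the number beyond the usual scatter of repeat measurements. At this level of activity, then, this methoxy group can be removed without a measurable loss, although this single step says nothing about other positions. No measured evidence bears on this result.

On these data alone, it remains open whether an amine or a carboxylic acid at this position would shift the number beyond the scatter. The contribution of the methoxy group that remains in compound 3 is also unknown, since no comparison here removes it.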